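Swapping the Halogenated Phenyl Group on the Saturated Ring Carbon

A few compounds are considered here, and "the series" means these few. Any claim that something is new, unique, unknown or untested is made for them only; others in the source may bear on it.

Compound 1, `CN1CC(=O)N(C)c2cnc(Nc3ccc(S(N)(=O)=O)cc3)nc21`: 495 nM
Compound 2, `CCCC1C(=O)N(C)c2cnc(Nc3ccc(S(N)(=O)=O)cc3)nc2N1C`: 206 nM
Compound 3, `CN1C(=O)C(c2ccc(F)cc2)N(C)c2nc(Nc3ccc(S(N)(=O)=O)cc3)ncc21`: 1770 nM

These three compounds share one core and differ only at a saturated ring carbon. In an assay on Sf9 cells for inhibition of serine/threonine-protein kinase 4 (Homo sapiens), read by luminescence and ADP-Glo, with a stated time of 1 h, in the presence of a further agent that is not named here (a lower number here means a stronger inhibitor, a higher number a weaker inhibitor), compound 3 stands at the highest number of the three, as seen in a 3.6-fold higher number from compound 1 to compound 3 (0.55 log units; beyond the scatter) and an 8.6-fold higher number from compound 2 to compound 3 (0.93 log units; beyond the scatter), while a 2.4-fold lower number from compound 1 to compound 2 (0.38 log units; beyond the scatter) runs the other way. Compound 4, `CN1C(=O)C(c2cccc(Cl)c2)N(C)c2nc(Nc3ccc(S(N)(=O)=O)cc3)ncc21`, differs from compound 3 by 3-chlorophenyl in place of 4-fluorophenyl on a saturated ring carbon. Going by the values given here, none of the measured steps replaces one substituted phenyl group with another; they only show that 4-fluorophenyl at this carbon gives higher numbers than hydrogen or propyl. Compound 4 is therefore expected to stay close to compound 3, a 1.0-fold higher number from compound 3 to compound 4 (0.01 log units; within the scatter), with no step beyond the scatter. The estimate for compound 4 is 1800 nM, with a range from 700 nM to 4500 nM.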

Compound 4, half-maximal inhibitory concentration: 989 nM
Beside the measured number, compound 4's estimate is 1.8-fold (0.26 log units) above it, within the range that was stated.
By their numbers in this assay, from the lowest: compound 2; then compounds 1, 4 and 3 (each within the scatter of the next, the first and the last beyond it).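

In this assay, a second substituted phenyl group can now be read at this saturated ring carbon: a 1.8-fold lower number from compound 3 to compound 4 (0.25 log units; within the scatter) leaves 3-chlorophenyl and 4-fluorophenyl indistinguishable here. Compound 4 also cannot be separated from hydrogen at this carbon, with a 2.0-fold higher number from compound 1 to compound 4 (0.30 log units; within the scatter) as the step, but propyl gives the lower number in a 4.8-fold higher number from compound 2 to compound 4 (0.68 log units; beyond the scatter) as a step beyond the scatter. Nothing measured here explains these numbers. On these data alone, the two phenyl groups differ in both the halogen and where it sits, so the effect of each remains unknown. As far as these compounds go, it also remains open how a butyl chain or an amine would compare with propyl at this carbon.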